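Isobutyl in Place of Isopropyl on a Ketone

A few compounds are considered here, and "the series" means these few. Any claim that something is new, unique, unknown or untested is made for them only; others in the source may bear on it.

Compound 1 `Cc1c(OCCCCOc2ccc(C(=O)O)cc2F)ccc(C(=O)CC2CCCC2)c1O`: in an assay on HEK293 cells for positive allosteric modulation of metabotropic glutamate receptor 3 (Rattus norvegicus), read by thallium flux, with a stated time of 2.5 min (on this read-out lower numbers stand for an effect already at smaller amounts and higher numbers for an effect only at larger amounts of compound), compound 1 gives > 10000 nM, which is a limit of the assay and not a number.
Compound 2 `COc1ccc(C(=O)O)cc1OCCCCOc1ccc(C(=O)C(C)C)c(O)c1C`: in this assay compound 2 gives 588 nM.
Compound 3 `Cc1c(OCCCCOc2ccc(F)c(C(=O)O)c2)ccc(C(=O)CC2CCCC2)c1C`: in this assay compound 3 gives "not determined" (no result reported), that is, no result was reported for it.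

Among these three compounds, compound 2 is the only one with a full number in this assay. Compound 1 sits at the limit described in the limit of > 10000 nM in this assay, at which 1 of the 3 values shown sits, and compound 3 has no result at all, so compound 2 cannot be ranked against either of them.

Compound 4 `COc1ccc(C(=O)O)cc1OCCCCOc1ccc(C(=O)CC(C)C)c(O)c1C` shares everything with compound 2 except the group on the ketone: isobutyl in place of isopropyl on a carbonyl carbon. The change is small, a single extra carbon on an alkyl chain beside the carbonyl, with no ring, no donor, no acceptor and no charge coming or going. Among the compounds with values here, no two measured compounds differ in only one place, so there is no measured step of this kind to lean on. Without such an anchor, the change from compound 2 to compound 4 is expected to stay within the usual scatter, in neither direction, and a 1.2-fold higher number from compound 2 to compound 4 (0.08 log units; within the scatter) expresses that expectation. In this assay compound 4 is therefore estimated at 700 nM, with a range from 250 nM to 2500 nM.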

Compound 4, half-maximal effective concentration: 737 nM
For compound 4 the middle estimate is 1.1-fold (0.02 log units) below the measured one, and the stated range covers the measured number.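

Within the data shown here, compound 2 and compound 4 are the first pair here that differ in only one place, so this assay now gives a measured step for this change on a carbonyl carbon: a 1.3-fold higher number from compound 2 to compound 4 (0.10 log units; within the scatter). A step of this size means that isopropyl and isobutyl at this position cannot be told apart on this read-out, and any real difference between them is hidden by the ordinary spread of repeated measurements. The position therefore accepts isobutyl in place of isopropyl with the activity still measurable as a full number, but nothing shown here accounts for that result at the level of the molecule.

This is a single pair with a small change, and it says nothing about whether a much longer chain, a phenyl ring or an amine on the same carbonyl carbon would also stay within the scatter. Compound 1 and compound 3 differ from compound 2 in more than one place, so they cannot settle that question either.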